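Acyl replacement on the ring nitrogen of the alkyne series

This account rests on a few compounds, and the source may have more. Where it says the series, first, only, none or still open, it means among the compounds named here.

Compound 1 `CCN1CCc2nc(C#Cc3ccccc3)sc2C1` in an assay on HEK293 cells for positive allosteric modulation of metabotropic glutamate receptor 5 (Homo sapiens), read by FLIPR, with a stated time of 1 h (on this read-out lower numbers stand for an effect already at smaller amounts and higher numbers for an effect only at larger amounts of compound), reaches only the assay limit, > 10000 nM (the limit of > 10000 nM in this assay, at which 1 of the 3 values shown sits). Compound 2 `CCCCN1CCc2nc(C#Cc3ccccc3)sc2C1` gives 110 nM, the step being an at least 90-fold lower number from compound 1 to compound 2 (1.95 log units; beyond the scatter). Compound 3 `O=C(C1CC(F)C1)N1CCc2nc(C#Cc3ccccc3)sc2C1` gives 85 nM; from the limit this is an at least 110-fold lower number from compound 1 to compound 3 (2.07 log units; beyond the scatter), and against compound 2 it is a 1.3-fold lower number from compound 2 to compound 3 (0.11 log units; within the scatter), so the two stand together. Compound 4 `CC1CCCC(C(=O)N2CCc3nc(C#Cc4ccccc4)sc3C2)C1` differs from compound 3 by 3-methylcyclohexyl in place of 3-fluorocyclobutyl on a carbonyl carbon. Within the data shown here, only the step of a 1.3-fold lower number from compound 2 to compound 3 (0.11 log units; within the scatter) touches the acyl group on the ring nitrogen, and it lay within the scatter; no measured step varies the ring on the carbonyl carbon. For compound 4 the expected step is therefore a 1.2-fold higher number from compound 3 to compound 4 (0.07 log units; within the scatter), and the estimated value for compound 4 is 100 nM with a range of 35 nM to 350 nM.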

Compound 4, half-maximal effective concentration: 100 nM
Beside the measured number, compound 4's estimate shows no gap at the digits printed; measured number inside the range.
By their numbers in this assay, from the lowest: compounds 3, 4 and 2 (each within the scatter of the next). At a limit, above all of these: compound 1.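

In this assay, 3-methylcyclohexyl and 3-fluorocyclobutyl on the carbonyl carbon stand level, with a 1.2-fold higher number from compound 3 to compound 4 (0.07 log units; within the scatter). So this place accepts a six-membered carbon ring with 7 heavy atoms as readily as a four-membered ring with 5, and fluorine is not required for this level of reading. The compounds shown give no reason for this result.

Open, on these data alone, is whether a ring carrying an amine or a carboxylic acid, or a longer chain, on the carbonyl carbon would stay level with compound 3. As far as these compounds go, the separate contributions of ring size and of the fluorine or methyl also remain open, since these change together here.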